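A few compounds are considered here, and "the series" means these few. Any claim that something is new, unique, unknown or untested is made for them only; others in the source may bear on it.

Measured so far:
Compound 1, `COc1cc(C(=O)OC2=C(CC=C(C)C)C(=O)[C@@]3(C(=O)C(C)C)C(=O)[C@]2(CC=C(C)C)C[C@H](CC=C(C)C)[C@@]3(C)CCC=C(C)C)cc(OC)c1OC`: "not determined" (no result reported).
Compound 2, `CC(C)CCC[C@]1(C)[C@@H](CCC(C)C)C[C@@]2(CCC(C)C)C(=O)[C@]1(C(=O)C(C)C)C(=O)C(CCC(C)C)=C2O`: 2120 nM; 3120 nM (2 entries).
Compound 3, `CC(C)=CCC[C@]1(C)[C@@H](CC=C(C)C)C[C@]2(CC=C(C)C)C(=O)C(Cl)(CC=C(C)C)C(=O)[C@@]1(C(=O)C(C)C)C2=O`: "not determined" (no result reported).

In an ADME assay on L6 cells (Rattus norvegicus) for cytotoxicity, with a stated time of 72 h (a higher number here means a weaker inhibitor, a lower number a stronger inhibitor), compound 1 stands without a single number, and the same holds for compound 3. Only compound 2 has a result, and the several entries of compound 2 in this assay, 2120 nM; 3120 nM (2 entries) shows that its repeated entries sit close together. Compound 4, `CC(C)=CCC[C@]1(C)[C@@H](CC=C(C)C)C[C@@]2(CC=C(C)C)C(=O)[C@]1(C(=O)C(C)C)C(=O)C(CC=C(C)C)=C2OC(=O)c1cccnc1`, arises from compound 1 by one change: pyridin-3-yl in place of 3,4,5-trimethoxyphenyl on a carbonyl carbon. Among the measured compounds shown here, no pair of measured compounds differs in one place, so the size of this step cannot be read from the data; the expectation is a step within the usual scatter of this assay, in no particular direction. Because compound 2 gives 2120 nM; 3120 nM (2 entries) in this assay, compound 4 is expected near 3000 nM, with a range from 800 nM to 12000 nM.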

Compound 4, half-maximal inhibitory concentration: 23900 nM
Estimate against measurement, compound 4: 8.0-fold (0.90 log units) below; the whole stated range lies below it.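

In this assay, among the compounds shown here, compound 4 gives 23900 nM, but compound 1 has no single number, so no step between compound 1 and compound 4 can be read. As far as these compounds go, what replacing 3,4,5-trimethoxyphenyl with pyridin-3-yl does on its own stays open.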